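Piperazinyl for Benzylamino: Expected Solubility of Compound 3

A few compounds are considered here, and "the series" means these few. Any claim that something is new, unique, unknown or untested is made for them only; others in the source may bear on it.

Measured so far in a physicochemical assay for solubility, in phosphate buffer, at pH 6.5; a higher number here means a more soluble compound, a lower number a less soluble compound:
Compound 1 `COc1nc(NCCCN(C)C)c2sc(-c3ccc(C(F)(F)F)cc3)cc2n1` gives < 5 ug/mL, which is a limit of the assay.
Compound 2 `CN(C)CCCNc1nc(NCc2ccccc2)nc2cc(-c3ccc(C(F)(F)F)cc3)sc12` gives < 5 ug/mL, also a limit.

Compound 2 thus stands at a limit, with no number read out, as both values share (the limit of < 5 ug/mL in this assay, at which 2 of the 2 values shown sit). Compound 3 `CN(C)CCCNc1nc(N2CCNCC2)nc2cc(-c3ccc(C(F)(F)F)cc3)sc12` differs from it by piperazin-1-yl in place of benzylamino on an aromatic carbon. Within the data shown here, the only measured step, a step that the two limits leave unreadable from compound 1 to compound 2, has no readable size, both of its ends being limits, so it offers no guide. In this assay an upward step is nonetheless expected, an at least 6.0-fold higher number from compound 2 to compound 3 (0.77 log units; beyond the scatter). Compound 3 is estimated at 30 ug/mL, within the range 5 ug/mL to 150 ug/mL, with a fair chance that only a limit is reported again.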

Compound 3, solubility: 178 ug/mL
Beside the measured number, compound 3's estimate is 5.9-fold (0.77 log units) below it; the whole stated range lies below it.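

In this assay, the aromatic carbon between two ring nitrogen atoms now proves able to carry a large change, an at least 35-fold higher number from compound 2 to compound 3 (1.55 log units; beyond the scatter), with piperazin-1-yl in place of benzylamino. Piperazin-1-yl in place of methoxy at that carbon gives an at least 35-fold higher number from compound 1 to compound 3 (1.55 log units; beyond the scatter). The step between compound 1 and compound 2 cannot be read, so benzylamino and methoxy cannot be ranked against each other, both values being limits: the limit of < 5 ug/mL in this assay, at which 2 of the 3 values shown sit.

From the compounds shown here alone, what stays open is whether the rise depends on the second nitrogen of piperazin-1-yl or on the ring as a whole. A morpholine or an open-chain amine at this carbon would tell these two apart.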